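The source may report more compounds than this note shows. Statements on the series, on what has been measured and on what is new or still open speak of the compounds shown alone.

Measured compounds:
- compound 1, `CC(=O)Nc1nc(-c2cccc(NS(=O)(=O)c3ccc(Br)cc3)c2)cs1`, in a functional assay on A-375 cells (Homo sapiens) for antiproliferative activity, read by trypan blue exclusion, with a stated time of 48 h, tested at 10 uM (a lower number here means a stronger effect, a higher number a weaker effect of the compound at the concentration tested), compound 1 gives 25.6%
- compound 2, `CC(=O)Nc1nc(-c2cccc(NS(=O)(=O)c3ccc(C#CCCc4ccccc4)cc3)c2)cs1`, in this assay compound 2 gives < 1%, which is a limit of the assay and not a number

Compound 2 stands at the floor of what this assay can report: its value is a limit, as noted in the limit of < 1% in this assay, at which 1 of the 2 values shown sits, so only its ceiling is known. Compound 1 sits clearly higher.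

Compound 3 is `CCCCCCc1ccc(S(=O)(=O)Nc2cccc(-c3csc(NC(C)=O)n3)c2)cc1`. It differs from compound 2 in one place: hexyl in place of 4-phenylbut-1-yn-1-yl on an aromatic carbon.

Among the measured compounds shown here, the only measured step, a number at least 24.6 percentage points lower from compound 1 to compound 2 (beyond the scatter), shows that swapping a small bromo for the long 4-phenylbut-1-yn-1-yl group at that position drove the read-out from a moderate value down to the limit. Hexyl is likewise a long group at the same position, so the expectation is that compound 3 stays close to where compound 2 lies, and the estimated step of a number at least 4 percentage points higher from compound 2 to compound 3 (that floor lies within the scatter) is none beyond the scatter. Compound 3 is therefore estimated at 5%, with a likely range from 0% to 25%, and a fair chance that only a limit is reported again.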

Compound 3, a percentage reported as activity, at one concentration (the size of the read-out at that concentration, not a potency): <= 1%
Compound 3: no number, only a limit; the forecaster's own chance of this, stated with the estimate: 40%; at least 4 percentage points between middle value and limit.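

In this assay, hexyl in place of bromo on an aromatic carbon gives a number at least 24.6 percentage points lower from compound 1 to compound 3 (beyond the scatter). Hexyl has no ring and no triple bond, so neither feature of 4-phenylbut-1-yn-1-yl is required for a fall of this size at this place, para to a large group; compound 2 and compound 3, the two compounds with a long group here, both reach the bottom of the reported range. Compound 2 and compound 3 both carry limits of the assay and not numbers, so the step between them cannot be read and neither can be ranked over the other: the limit of <= 1% in this assay, at which 1 of the 3 values shown sits.

From the compounds shown here alone, it remains open how short a carbon chain at this place can be and still give such a fall, for instance whether butyl or ethyl would do, and whether a chain ending in an amine or a carboxylic acid would behave like hexyl. The read-out is taken at one concentration, and it gives no potency for any of the three compounds.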